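Cyclohexyl for methoxyphenyl on the aryloxy chain

The source may report more compounds than this note shows. Statements on the series, on what has been measured and on what is new or still open speak of the compounds shown alone.

Measured compounds:
- Compound 1 `C[C@](N)(COP(=O)(O)O)C(=O)Nc1ccc(OCCc2cccc3ccccc23)cc1`: "not determined" (no result reported)
- Compound 2 `C[C@](N)(COP(=O)(O)O)C(=O)Nc1ccc(OCCCCCc2ccccc2)cc1`: 3.6 nM
- Compound 3 `COc1ccc(CCCCOc2ccc(NC(=O)[C@@](C)(N)COP(=O)(O)O)cc2)cc1`: "not determined" (no result reported)

The series shares one phosphonated amino-amide core and varies the group carried on the chain that hangs from the aryl oxygen. Going by the values given here, in an assay on isolated protein for displacement of a labelled ligand from sphingosine 1-phosphate receptor 4 (Homo sapiens) (a lower number here means a stronger inhibitor, a higher number a weaker inhibitor), compound 2 gives 3.6 nM, and it is the only member with a number. In this assay compound 3 has "not determined" (no result reported), so where it stands cannot be said from the numbers; it is joined only by compound 1, which in this assay has "not determined" (no result reported) as well.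

Compound 4 `C[C@](N)(COP(=O)(O)O)C(=O)Nc1ccc(OCCCCC2CCCCC2)cc1` differs from compound 3 in a single place: cyclohexyl in place of 4-methoxyphenyl on a saturated chain carbon, four bonds along the chain from an oxygen on an aromatic ring. Among the compounds with values here, no measured pair shows this kind of change, so its size cannot be read from a step. Within the data shown here, since compound 3 has no number, the only anchor is compound 2, which also carries a six-membered ring at the end of a chain of the same length. The writer therefore expects compound 4 to land close to compound 2, any difference from compound 2 likely staying within the scatter. Compound 4 is estimated at 6 nM, within 1.5 nM to 25 nM.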

Compound 4, half-maximal inhibitory concentration: 8.3 nM
Beside the measured number, compound 4's estimate is 1.4-fold (0.14 log units) below it; low and high end bracket the measured number.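

In this assay, going by these compounds alone, the series now shows a 2.3-fold higher number from compound 2 to compound 4 (0.36 log units; beyond the scatter), the first measured step at this end of the chain. A non-aromatic ring of carbon only is therefore accepted here, with compound 4 still reaching 8.3 nM, though the number is higher than with the benzyl group of compound 2. Nothing in the data explains this rise.

The swap of 4-methoxyphenyl for cyclohexyl itself cannot be read, since compound 3 has no number, and the step that can be read replaces benzyl, so the ring and a chain carbon change together. The compounds shown leave open whether a phenyl or a cyclohexyl on the same chain differ at all, and how a longer chain, or an amine or a carboxylic acid on the cyclohexyl ring, would fare.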